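Swapping benzylselanyl for methylsulfanyl on the quinoline pair

This account rests on a few compounds, and the source may have more. Where it says the series, first, only, none or still open, it means among the compounds named here.

Measured so far in a functional assay on HepG2 cells (Homo sapiens) for cytotoxicity, read by MTT assay, with a stated time of 72 h; a lower number here means a stronger inhibitor of growth, a higher number a weaker inhibitor of growth:
Compound 1 `O=C(/N=C(/NC(=O)c1cc(-c2ccccc2)nc2ccccc12)[Se]Cc1ccccc1)c1cc(-c2ccccc2)nc2ccccc12` gives 52400 nM.
Compound 2 `O=C(/N=C(/NC(=O)c1cccs1)[Se]Cc1ccccc1)c1cccs1` gives 58100 nM.
Compound 3 `CS/C(=N\C(=O)c1cccs1)NC(=O)c1cccs1` gives > 100000 nM, which is a limit of the assay rather than a number.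

Among the two numbers, compound 1 stands lowest, and compound 2 sits within the usual scatter of it, so no order between them can be claimed. Compound 3 sits at the limit of > 100000 nM in this assay, at which 1 of the 3 values shown sits.

Compound 4 `CS/C(=N\C(=O)c1cc(-c2ccccc2)nc2ccccc12)NC(=O)c1cc(-c2ccccc2)nc2ccccc12` differs from compound 1 in one place: a group of 2 heavy atoms (1 carbon, 1 sulfur; no ring) in place of a group of 8 heavy atoms (7 carbon, 1 selenium; one six-membered aromatic ring of carbon only), on a carbon with a double bond to nitrogen. The same exchange has been measured once, on the thiophene pair, as an at least 1.7-fold higher number from compound 2 to compound 3 (0.23 log units; that floor lies within the scatter); that floor lies within the scatter, yet the change ended at a limit, so the real shift may be larger. The expectation for compound 4 is therefore a move towards a higher number, quite possibly beyond what the assay reports, estimated as a 2.1-fold higher number from compound 1 to compound 4 (0.32 log units; beyond the scatter). Compound 4 is thus expected near 110000 nM, within a range from 45000 nM to 300000 nM.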

Compound 4, concentration for total growth inhibition: 48200 nM
Beside the measured number, compound 4's estimate is 2.3-fold (0.36 log units) above it, and the stated range covers the measured number.
By their numbers in this assay, from the lowest: compounds 4, 1 and 2 (each within the scatter of the next). At a limit, above all of these: compound 3.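

In this assay, exchanging the selenium-bearing group for methylsulfanyl, on a carbon with a double bond to nitrogen, gives a 1.1-fold lower number from compound 1 to compound 4 (0.04 log units; within the scatter), so compound 1 and compound 4 cannot be told apart. On this core, then, a number in this range does not depend on keeping the selenium-bearing group with its six-membered aromatic ring, and methylsulfanyl does not have to end at a limit of the assay. The same exchange can now be read on two cores: the same change on two cores in this assay, an at least 1.7-fold higher number (0.23 log units; that floor lies within the scatter) from compound 2 to compound 3 and a 1.1-fold lower number (0.04 log units; within the scatter) from compound 1 to compound 4; the limit leaves it open whether they differ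

Selenium and the benzyl ring leave together in this exchange, and the separate part played by each stays open. A benzylsulfanyl or methylselanyl group on the same carbon would pull the two apart, and an amine there would test whether a sulfur or selenium link is needed at all.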